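Removing One Methoxy Group from Compound 3

The source may report more compounds than this note shows. Statements on the series, on what has been measured and on what is new or still open speak of the compounds shown alone.

In a functional assay on MDA-MB-435 cells (Homo sapiens) for antiproliferative activity, read by sulforhodamine B assay, with a stated time of 48 h (on this read-out higher numbers stand for weaker inhibition and lower numbers for stronger inhibition), compound 3 `COc1ccc(C2=NN(C(C)=O)C(c3cc(OC)c(OC)c(OC)c3)O2)cc1` gives 140 nM. Compound 1 `COc1cc(C2=NN(C(C)=O)C(c3cccc(Br)c3)O2)cc(OC)c1OC` gives 150 nM and compound 2 `COc1ccc(C2=NN(C(C)=O)C(c3cc(OC)ccc3OC)O2)cc1` gives 200 nM. Both values lie within the usual scatter of compound 3, so these three compounds cannot be ranked on these numbers.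

Compound 4 `COc1ccc(C2=NN(C(C)=O)C(c3cc(OC)cc(OC)c3)O2)cc1` has hydrogen in place of methoxy on an aromatic carbon, at the position ortho to two methoxy groups and para to a large group: hydrogen in place of methoxy on an aromatic carbon. Among the measured compounds shown here, no measured pair here differs by this single change, so any forecast is only a rough one.

Compared with compound 3, the same ring carries fewer methoxy groups in compound 2, which gives 200 nM, and this suggests that the loss need not be large. A small shift towards weaker inhibition is expected, with an estimated 1.8-fold higher number from compound 3 to compound 4 (0.25 log units; within the scatter). The estimate for compound 4 is 250 nM, with an expected range from 80 nM to 800 nM.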

Compound 4, half-maximal inhibitory concentration in the MDA-MB-435 assay: 110 nM
Beside the measured number, compound 4's estimate is 2.3-fold (0.36 log units) above it; measured number inside the range.
By their numbers in the MDA-MB-435 assay, from the lowest: compounds 4, 3, 1 and 2 (each within the scatter of the next).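

In the MDA-MB-435 assay the step reads a 1.3-fold lower number from compound 3 to compound 4 (0.10 log units; within the scatter), so the methoxy group at this position, ortho to two methoxy groups and para to a large group, can give way to hydrogen with no measurable loss of inhibition. In a physicochemical assay for solubility, at pH 7.4 (on this read-out higher numbers stand for higher solubility and lower numbers for lower solubility), compound 3 gives 257000 nM and compound 4 gives 94000 nM, so the same change does register: the measured solubility of compound 3, 257000 nM, and of compound 4, 94000 nM, a 2.7-fold lower number (0.44 log units; beyond the scatter). Among the compounds shown here, these are the first two compounds here that differ in one place, and in this pair the methoxy group matters in the physicochemical assay but not measurably in the MDA-MB-435 assay.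

The compounds shown leave open what a group other than methoxy or hydrogen, such as an amine or a carboxylic acid, would do at this position in either the MDA-MB-435 assay or the physicochemical assay. Going by these compounds, the change is also seen in a single pair, so whether it behaves alike on the other aromatic ring remains open.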